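From Piperidin-1-yl to (Oxan-4-yl)amino at a Limit

The source may report more compounds than this note shows. Statements on the series, on what has been measured and on what is new or still open speak of the compounds shown alone.

In an ADME assay on microsomes from liver (Mus musculus) for metabolic stability, tested at 5 uM (on this read-out higher numbers stand for a longer-lived compound and lower numbers for a shorter-lived compound), compound 1 `COCCCCNc1ccc(C(=O)O)cc1S(=O)(=O)N(C)C` gives > 1 h, which is a limit of the assay and not a number. Compound 2 `O=C(O)c1ccc(NCCCCCCCC(F)(F)F)c(S(=O)(=O)N2CCCCC2)c1` gives > 1 h in this assay, and this too is a limit. For the measured compounds named here, what the data offer is therefore (the limit of > 1 h in this assay, at which 2 of the 2 values shown sit), so no order can be drawn between the two compounds and no measured step is available to go by.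

Compound 3 `O=C(O)c1ccc(NCCCCCCCC(F)(F)F)c(S(=O)(=O)NC2CCOCC2)c1` has not yet been measured. It carries (oxan-4-yl)amino in place of piperidin-1-yl on a sulfonyl sulfur, while the rest of compound 2 stays as it is.

In this assay, no step beyond the scatter is expected, and no direction can be called. The expectation rests on compound 2, which gives > 1 h, a limit. The estimated step that the limit leaves unreadable from compound 2 to compound 3 is expected to stay within the scatter. There is a good chance that the assay will again report only a limit. For compound 3 the expected half-life is 1.5 h, with an estimated range of 0.7 h to 4 h.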

Compound 3, half-life in the Mus musculus assay: > 1 h
Compound 3: a limit, no number; the forecaster's own chance of this, stated with the estimate: 75%; the middle value does not contradict the limit.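

In the Mus musculus assay compound 3 gives > 1 h, which is again a limit and not a number. No step can be read from compound 2 to compound 3 on this read-out. The compounds shown leave open whether this exchange on the sulfonyl sulfur alters the half-life at all, and how the three compounds rank on it: the limit of > 1 h in the Mus musculus assay, at which 3 of the 3 values shown sit.

In a physicochemical assay for solubility, in phosphate buffer, measured as kinetic solubility, at pH 7.4, tested at 250 uM (on this read-out higher numbers stand for higher solubility and lower numbers for lower solubility), compound 2 gives 13000 nM, and compound 3 gives 244000 nM. In the physicochemical assay the exchange makes a 19-fold higher number from compound 2 to compound 3 (1.27 log units; beyond the scatter).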